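The compounds below may be only part of what the source reports. "The series", "measured", "known", "first", "only" and "open" are said of these compounds alone.

Working notes on the series in an assay on isolated protein (Asteroidea) for inhibition of G2/mitotic-specific cyclin-B (Asterina pectinifera), read by scintillation counting and 33P incorporation, with a stated time of 30 min; on this read-out lower numbers stand for stronger inhibition and higher numbers for weaker inhibition.

Of the compounds shown here, three have numbers so far. Compound 1 `CC(C)n1cnc2c(Nc3cccc(-c4ncccn4)c3)nc(Cl)nc21` gives 10000 nM in this assay. Compound 2 `CCC[C@@H](O)Nc1nc(Nc2ccc(-c3cncnc3)cc2)c2ncn(C(C)C)c2n1` gives 40 nM. Compound 3 `CCC[C@@H](O)Nc1nc(Nc2cccc(-c3ncccn3)c2)c2ncn(C(C)C)c2n1` gives 300 nM, which places compound 3 second highest of the three numbers: compound 2 sits nearest, and compound 1 furthest. Within the data shown here, the one single-point step measured so far is a 33-fold lower number from compound 1 to compound 3 (1.52 log units; beyond the scatter), a group of 6 heavy atoms (4 carbon, 1 nitrogen, 1 oxygen; no ring) in place of one chlorine atom on an aromatic carbon. Among the measured compounds shown here, compound 2 and compound 3 share that group and differ in the placement of their ring substituents, for which no single-point step is recorded; their two values simply stand as given.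

Compound 4 `CCC[C@H](O)Nc1nc(Nc2cccc(-c3ncccn3)c2)c2ncn(C(C)C)c2n1` is the next candidate. Against compound 3 the change is the two compounds have the same atoms and bonds and differ only in configuration as drawn: 1 of 1 stereo elements differ; a stereocentre at a saturated chain carbon is drawn R in compound 3 and S in compound 4: the two compounds have the same atoms and bonds and differ only in configuration as drawn, a stereocentre at a saturated chain carbon being R in compound 3 and S in compound 4. For the measured compounds named here, none of the measured steps involves a change of configuration, so nothing among the numbers bears on this step directly. Inverted centres in a series can leave the number untouched or move it either way; with no anchor, the expectation is set near compound 3 with a wide spread, the expected step being a 1.3-fold higher number from compound 3 to compound 4 (0.12 log units; within the scatter). Compound 4 is therefore estimated at 400 nM, within 100 nM to 2000 nM.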

Compound 4, half-maximal inhibitory concentration: 730 nM
Compound 4: middle estimate off by 1.8-fold (0.26 log units), on the low side; the measured number falls inside the stated range.
By their numbers in this assay, from the lowest: compound 2; then compound 3; then compound 4; then compound 1.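

In this assay the configuration of the stereocentre at a saturated chain carbon carries weight, with a 2.4-fold higher number from compound 3 to compound 4 (0.39 log units; beyond the scatter), and that gap can be placed on the centre alone because of one fact: the fact that compounds 3 and 4 differ only in the configuration as drawn

The replacement of the chlorine atom by the group of 6 heavy atoms still lowers the number with the centre drawn S, with a 14-fold lower number from compound 1 to compound 4 (1.14 log units; beyond the scatter), so the large step seen earlier, a 33-fold lower number from compound 1 to compound 3 (1.52 log units; beyond the scatter), is not confined to the R form. Configuration therefore changes the size of that step without removing it, and the lower number of this pair belongs to the R form in compound 3.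

Among these compounds, still open is whether the same order of R and S holds with the ring arrangement of compound 2, the lowest number so far. Also open, from the compounds shown here alone, is how the stereocentre behaves when its substituents change, for example with a methyl ether in place of the hydroxyl or with a longer chain in place of the propyl chain.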